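The compounds below may be only part of what the source reports. "The series", "measured", "known", "first", "only" and "open" are said of these compounds alone.

Working notes on the series, read in a functional assay on HepG2 cells (Homo sapiens) for cytotoxicity, read by MTT assay, with a stated time of 72 h; on this read-out higher numbers stand for weaker inhibition and lower numbers for stronger inhibition. Compound 1 `CNC(=O)c1cc(Oc2ccc(C(=O)/C=C/c3ccco3)cc2)ccn1` has "not determined" (no result reported). Compound 2 `CNC(=O)c1cc(Oc2ccc(C(=O)/C=C/c3ccc(Br)cc3)cc2)ccn1` gives > 50000 nM, which is a limit of the assay and not a number. Compound 3 `CNC(=O)c1cc(Oc2ccc(C(=O)/C=C/c3ccc([N+](=O)[O-])cc3)cc2)ccn1` has "not determined" (no result reported), so it holds no place on the numbers. The only other entries beside it are one limit and one missing result.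

Compound 4 `CNC(=O)c1cc(Oc2ccc(C(=O)/C=C/c3ccc(F)cc3Cl)cc2)ccn1` is still to be measured. The change leading to it is 2-chloro-4-fluorophenyl in place of 4-nitrophenyl on a double-bonded chain carbon bound to a double-bonded chain carbon, with 2-chloro-4-fluorophenyl in place of 4-nitrophenyl on a double-bonded chain carbon bound to a double-bonded chain carbon.

Going by the values given here, the series offers no measured step, and compound 3 offers no number to step from, so the size of this step cannot be read from the data. Among the compounds with values here, the only anchor is compound 2, whose > 50000 nM is a limit. Weak inhibition is expected, with only a modest move toward stronger inhibition relative to that limit.

Compound 4 is estimated at 25000 nM, with an expected range of 6000 nM to 50000 nM.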

Compound 4, half-maximal inhibitory concentration: 7320 nM
Beside the measured number, compound 4's estimate is 3.4-fold (0.53 log units) above it; measured number inside the range.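

In this assay, the aryl group on a double-bonded chain carbon bound to a double-bonded chain carbon now proves able to move the read-out: 2-chloro-4-fluorophenyl in place of 4-bromophenyl gives an at least 6.8-fold lower number from compound 2 to compound 4 (0.83 log units; beyond the scatter). Going by these compounds alone, compound 4 carries the first single number, while steps involving compound 1 or compound 3 cannot be read. Compound 2 stands at a limit and not a number, which leaves the step with no exact size: the limit of > 50000 nM in this assay, at which 1 of the 4 values shown sits.

The compounds shown leave open whether the chlorine, the fluorine or the pair of them accounts for the step, as 2-chlorophenyl and 4-fluorophenyl do not appear alone. Also open, on these data alone, is how an aryl group bearing an amine, such as 4-aminophenyl, or a methoxy group, such as 4-methoxyphenyl, would read at this position.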